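The source may report more compounds than this note shows. Statements on the series, on what has been measured and on what is new or still open speak of the compounds shown alone.

Among the compounds with values here, in a functional assay on HeLa cells (Homo sapiens) for antiproliferative activity, read by sulforhodamine B assay, with a stated time of 72 h (a higher number here means a weaker inhibitor, a lower number a stronger inhibitor), compound 1 `FC(F)(F)c1cccc(/C=C\c2cc3ccccc3nc2Cl)c1` gives 2850 nM, the lower of the two numbers measured so far. Compound 2 `FC(F)(F)c1cccc(/C=C/c2cc3ccccc3nc2Cl)c1` gives 20300 nM. The measured change is a 7.1-fold higher number from compound 1 to compound 2 (0.85 log units; beyond the scatter), and it goes with the fact that compounds 1 and 2 differ only in the configuration as drawn. Compound 3 `COc1ccc2nc(Cl)c(/C=C\c3cccc(C(F)(F)F)c3)cc2c1` keeps the double bond drawn Z and has methoxy in place of hydrogen on an aromatic carbon. Within the data shown here, no measured step tests this kind of change, and the step in configuration gives no direction for it. The expected change is small, with an estimated 1.1-fold lower number from compound 1 to compound 3 (0.06 log units; within the scatter). Compound 3 is estimated at 2500 nM, with an expected range from 700 nM to 9000 nM.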

Compound 3, half-maximal inhibitory concentration: 3030 nM
Estimate against measurement, compound 3: 1.2-fold (0.08 log units) below; the range from low to high includes it.
By their numbers in this assay, from the lowest: compounds 1 and 3 (each within the scatter of the next); then compound 2.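

In this assay, methoxy in place of hydrogen on an aromatic carbon, meta to a fused ring and para to a fused ring, gives a 1.1-fold higher number from compound 1 to compound 3 (0.03 log units; within the scatter). This position of the shared core therefore accepts methoxy, with the double bond drawn Z, without a step beyond the scatter, something compounds 1 and 2 could not show, since they differ only in configuration. Nothing measured here accounts for this result. On these data alone, whether an amine or a carboxylic acid at this position would fare the same remains open. So does the effect of methoxy with the double bond drawn E.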